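Methyl for Hydrogen on the Phenol Oxygen

This account rests on a few compounds, and the source may have more. Where it says the series, first, only, none or still open, it means among the compounds named here.

Measured compounds:
Compound 1 `O=C(Nc1cccc(-n2cc(-c3ccncc3)c(-c3cc(O)cc(Cl)c3)n2)c1)Nc1ccc(Cl)c(C(F)(F)F)c1` gives 92% in a functional assay on MOLT-4 cells (Homo sapiens) for inhibition, read by sulforhodamine B assay, with a stated time of 48 h, tested at 0.1 uM; a lower number here means a stronger effect, a higher number a weaker effect of the compound at the concentration tested.
Compound 2 `O=C(Nc1cccc(-n2cc(-c3ccncc3)c(-c3cc(O)cc(Cl)c3)n2)c1)Nc1ccc(Cl)c(Cl)c1` gives 94% in this assay.

Compound 1 stands as the lower of the two numbers in this assay, with compound 2 nearest, but a number 2 percentage points higher from compound 1 to compound 2 (within the scatter) lies within the scatter, so the two are not distinguishable. Within the data shown here, the only measured step, chloro in place of trifluoromethyl on an aromatic carbon, sits far from the phenol and has no bearing on the change considered now. Compound 3 `COc1cc(Cl)cc(-c2nn(-c3cccc(NC(=O)Nc4ccc(Cl)c(C(F)(F)F)c4)c3)cc2-c2ccncc2)c1` differs from compound 1 by methyl in place of hydrogen on an oxygen on an aromatic ring. Among the measured compounds shown here, no measured pair shows this change, so there is no step to draw on. Both measured compounds give high numbers, and compound 3 is expected to behave alike, with a number 2 percentage points higher from compound 1 to compound 3 (within the scatter) expected to stay within the scatter. Compound 3 is therefore estimated at 94%, within a range of 84% to 103%.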

Compound 3, a percentage reported as activity, at one concentration (the size of the read-out at that concentration, not a potency): 57%
Estimate against measurement, compound 3: 37 percentage points above; the measured number lies below the stated range.
By their numbers in this assay, from the lowest: compound 3; then compounds 1 and 2 (each within the scatter of the next).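

In this assay, the step from hydroxy to methoxy on the 3-chloro-5-hydroxyphenyl group is a number 35 percentage points lower from compound 1 to compound 3 (beyond the scatter), and since a lower number means a stronger effect, the methoxy compound acts more strongly at the concentration tested. The earlier pair showed only a change on the other aromatic ring that stayed within the scatter, whereas this result shows that the read-out responds strongly to a single methyl placed on the phenol oxygen. Nothing measured here accounts for this step.

The compounds shown leave open whether an ethyl group on the same oxygen or an amine in place of the hydroxy would give a similar number. They also leave open whether the methyl step would hold in the chloro analogue, compound 2.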